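The source may report more compounds than this note shows. Statements on the series, on what has been measured and on what is new or still open speak of the compounds shown alone.

Compound 2 `CNc1ncnc2c1c(I)cn2[C@@H]1O[C@H](CO)[C@@H](O)[C@H]1O` sits at the edge of what the assay can resolve: in a functional assay on HCT-116 cells (Homo sapiens), read by MTT assay, with a stated time of 72 h (on this read-out lower numbers stand for stronger inhibition and higher numbers for weaker inhibition), compound 2 gives > 100000 nM, which is a limit of the assay and not a number (the limit of > 100000 nM in this assay, at which 1 of the 2 values shown sits). Among the measured compounds shown here, compound 1 `Cc1ncnc2c1c(I)cn2[C@@H]1O[C@H](CO)[C@@H](O)[C@H]1O` gives 7570 nM in this assay, and the only measured step, an at least 13-fold higher number from compound 1 to compound 2 (1.12 log units; beyond the scatter), concerns a different position. Compound 3 `CNc1ncnc2c1c(-c1ccoc1)cn2[C@@H]1O[C@H](CO)[C@@H](O)[C@H]1O` differs from compound 2 by furan-3-yl in place of iodo on an aromatic carbon. No measured step alters the iodo, so nothing shown bears on this change and no direction can be drawn. Compound 3 is therefore expected near the limit, around 70000 nM (range 15000 nM to 300000 nM). The expected step is thus an at least 1.4-fold lower number from compound 2 to compound 3 (0.15 log units; that floor lies within the scatter).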

Compound 3, half-maximal inhibitory concentration: > 20000 nM
Compound 3: a limit, no number (the forecaster's own chance of this, stated with the estimate: 55%); the middle value does not contradict the limit.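

Among the compounds shown here, compound 2 and compound 3 both give only limits, not numbers, in this assay, so no step between them can be read. The compounds shown leave open whether furan-3-yl in place of iodo raises, lowers or leaves unchanged the read-out.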